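The source may report more compounds than this note shows. Statements on the series, on what has been measured and on what is new or still open speak of the compounds shown alone.

Measured in a functional assay on BT-474 cells (Homo sapiens) for inhibition, read by MTT assay, with a stated time of 5 days; on this read-out higher numbers stand for weaker inhibition and lower numbers for stronger inhibition:
- Compound 1 (`Cc1cc(Nc2nc(NCc3ccc(Cl)cc3)nc3c2cnn3C2CCOCC2)n[nH]1`): 18300 nM
- Compound 2 (`Cc1cc(Nc2nc(NCc3ccc(Cl)cc3)nc3c2cnn3C(C)C)n[nH]1`): 13000 nM
- Compound 3 (`Cc1cc(Nc2nc(NCc3ccc(F)cc3F)nc3c2cnn3C2CCOCC2)n[nH]1`): 2350 nM

Compound 3 has the lowest number of the three in this assay. Its value of 2350 nM compares with 13000 nM for compound 2 and 18300 nM for compound 1.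

The next compound, compound 4 (`Cc1cc(Nc2nc(NCc3ccc(F)cc3F)nc3c2cnn3C(C)C)n[nH]1`), keeps the 2,4-difluorophenyl of compound 3 and changes one group: isopropyl in place of oxan-4-yl on an aromatic nitrogen. The same replacement, isopropyl in place of oxan-4-yl on an aromatic nitrogen, has been measured once, with 4-chlorophenyl in the molecule. That was a 1.4-fold lower number from compound 1 to compound 2 (0.15 log units; within the scatter). The other measured step, a 7.8-fold lower number from compound 1 to compound 3 (0.89 log units; beyond the scatter), is larger, but it concerns the swap of 4-chlorophenyl for 2,4-difluorophenyl and leaves the oxan-4-yl untouched. It explains nothing about the present change, though it does show that the aryl group can move the number.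

Among the compounds with values here, whether the single matched pair carries over to the 2,4-difluorophenyl series has not been tested. On that one pair, no change beyond the scatter is expected in this assay. The expected size is a 1.2-fold lower number from compound 3 to compound 4 (0.09 log units; within the scatter). Compound 4 is estimated at 1900 nM, with an expected range from 850 nM to 4200 nM.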

Compound 4, half-maximal inhibitory concentration: 17300 nM
Estimate against measurement, compound 4: 9.1-fold (0.96 log units) below, and the stated range ends below it.
By their numbers in this assay, from the lowest: compound 3; then compounds 2, 4 and 1 (each within the scatter of the next).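

With 2,4-difluorophenyl in the molecule, isopropyl in place of oxan-4-yl on an aromatic nitrogen gives, in this assay, a 7.4-fold higher number from compound 3 to compound 4 (0.87 log units; beyond the scatter), so the outcome of this replacement depends on the aryl group elsewhere in the molecule, and the absence of a clear step with 4-chlorophenyl does not carry over: the same change on two cores in this assay, a 1.4-fold lower number (0.15 log units; within the scatter) from compound 1 to compound 2 and a 7.4-fold higher number (0.87 log units; beyond the scatter) from compound 3 to compound 4, 10-fold (1.02 log units) apart, beyond the scatter of two such steps

Read the other way, with isopropyl on the aromatic nitrogen, 2,4-difluorophenyl in place of 4-chlorophenyl gives a 1.3-fold higher number from compound 2 to compound 4 (0.12 log units; within the scatter), so the drop seen with oxan-4-yl present does not appear here either: the same change on two cores in this assay, a 7.8-fold lower number (0.89 log units; beyond the scatter) from compound 1 to compound 3 and a 1.3-fold higher number (0.12 log units; within the scatter) from compound 2 to compound 4, 10-fold (1.02 log units) apart, beyond the scatter of two such steps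

Among the four compounds, only compound 3, which pairs oxan-4-yl with 2,4-difluorophenyl, stands apart, while the other three lie within the scatter of each other.

The compounds shown leave open whether the ring of oxan-4-yl or its oxygen matters in this pairing, a question that a cyclohexyl on the same nitrogen, with the ring but no oxygen, could separate. Also open, going by these compounds, is whether both fluorines are needed, which 4-fluorophenyl or 2-fluorophenyl alongside oxan-4-yl could address.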